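Hexyl to 2-Chlorobenzyl on a Piperidine Nitrogen

A few compounds are considered here, and "the series" means these few. Any claim that something is new, unique, unknown or untested is made for them only; others in the source may bear on it.

Compounds measured so far:
- compound 1, `COc1ccc2nccc(C3CN(C4CCN(Cc5c[nH]c6ccccc56)CC4)C(=O)O3)c2c1`: < 50200 nM in an in vitro functional assay on RBL cells for antagonist activity at C-C chemokine receptor type 8 (Homo sapiens), read by FLIPR and calcium flux; on this read-out higher numbers stand for weaker inhibition and lower numbers for stronger inhibition
- compound 2, `CCCCCCN1CCC(N2CC(c3ccnc4ccc(OC)cc34)OC2=O)CC1`: 501 nM

Compound 1 gives only a limit of the assay, < 50200 nM, and the limit of < 50200 nM in this assay, at which 1 of the 2 values shown sits, shows that one of the two values sits at it. For the measured compounds named here, compound 2 therefore stands as the only real number among the values shown, at 501 nM. The step that the limit leaves unreadable from compound 1 to compound 2 cannot be read in size, since one end of it is a limit.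

Compound 3, `COc1ccc2nccc(C3CN(C4CCN(Cc5ccccc5Cl)CC4)C(=O)O3)c2c1`, has not yet been measured. It differs from compound 2 by 2-chlorophenyl in place of pentyl on a saturated chain carbon bound to an amine nitrogen in a ring. Going by the values given here, no measured step covers a change of this kind, so the expected size is guessed rather than read; compound 1 shows only that a different ring group at this place gave a limit.

The estimate for compound 3 is 1200 nM, between 200 nM and 8000 nM, meaning an expected step of a 2.4-fold higher number from compound 2 to compound 3 (0.38 log units; beyond the scatter).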

Compound 3, half-maximal inhibitory concentration: < 50200 nM
Compound 3: only a limit was reported; the forecaster's own chance of this, stated with the estimate: 20%; the middle value does not contradict the limit.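

Compound 3, like compound 1, gives only a limit, not a number: the limit of < 50200 nM in this assay, at which 2 of the 3 values shown sit. For the compounds shown here, no step from compound 1 or compound 2 to compound 3 can therefore be read in size. Going by these compounds, how the 2-chlorobenzyl and hexyl groups actually compare on the shared core remains open.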